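Adding Bromine to Compound 1: an Expected Effect

A few compounds are considered here, and "the series" means these few. Any claim that something is new, unique, unknown or untested is made for them only; others in the source may bear on it.

Compound 1 `C=CCOc1c(C)c(C)c2c(c1C)CCC(C)(COc1ccc(/C=C3\SC(=O)NC3=O)cc1)O2` gives 2%.
Compound 2 `Cc1c(C)c2c(c(C)c1OC/C=C/c1ccccc1)CCC(C)(COc1ccc(/C=C3\SC(=O)NC3=O)cc1)O2` gives 43%.
Compound 3 `Cc1c(C)c2c(c(C)c1OCc1ccccc1)CCC(C)(COc1ccc(/C=C3\SC(=O)NC3=O)cc1)O2` gives 12%.

These three values come from a functional assay on MCF7 cells (Homo sapiens), tested at 7.5 uM; on this read-out higher numbers stand for a weaker effect at the one concentration tested and lower numbers for a stronger effect. Compound 1 stands lowest of the three, which on this read-out means the strongest effect; compound 3 lies closest, with a difference that stays within the scatter, and compound 2 lies furthest. The measured steps all change the group on the saturated chain carbon bound to the ring oxygen: a number 41 percentage points higher from compound 1 to compound 2 (beyond the scatter), a number 10 percentage points higher from compound 1 to compound 3 (within the scatter) and a number 31 percentage points lower from compound 2 to compound 3 (beyond the scatter).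

Compound 4 `C=CCOc1c(C)c(C)c2c(c1C)CCC(C)(COc1ccc(/C=C3\SC(=O)NC3=O)cc1Br)O2` keeps everything of compound 1 and changes a different place: bromo in place of hydrogen on an aromatic carbon. For the measured compounds named here, none of the measured steps touches this position, so no step bears directly on it, and the data give no guide to its size. Compound 1 already sits near the floor of the read-out, so the number can hardly fall further; compound 4 is therefore expected to stay close to compound 1, with an estimated step of a number 10 percentage points higher from compound 1 to compound 4 (within the scatter), giving an expected value of 12% with a range from 1% to 45%.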

Compound 4, a percentage reported as activity, at one concentration (the size of the read-out at that concentration, not a potency): 105%
Beside the measured number, compound 4's estimate is 93 percentage points below it; the measured number lies above the stated range.
By their numbers in this assay, from the lowest: compounds 1 and 3 (each within the scatter of the next); then compound 2; then compound 4.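

Placing a single bromo in place of hydrogen on an aromatic carbon, ortho to a large group, moves the read-out in this assay sharply upward, with a number 103 percentage points higher from compound 1 to compound 4 (beyond the scatter). Higher numbers here mean a weaker effect, so the strong effect of compound 1 does not survive this change, even though only one heavy atom enters. The earlier steps shown here all changed the group on the chain carbon and none came close to this size, so this aromatic carbon turns out to be far more sensitive to change than those steps could reveal.

Nothing available explains why this one atom has such a large effect. On these data alone, whether a fluoro or a methoxy group on the same aromatic carbon would weaken the effect as much also remains open.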